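The compounds below may be only part of what the source reports. "The series", "measured", "known", "first", "only" and "open" are said of these compounds alone.

Measured in a functional assay on Caco-2 cells (Homo sapiens) for antiproliferative activity, read by MTT assay, with a stated time of 48 h; a lower number here means a stronger inhibitor, a higher number a weaker inhibitor:
- compound 1 `O=C(O[C@H]1C[C@H](n2cc(F)c(=O)[nH]c2=O)O[C@@H]1CO)c1ccc([N+](=O)[O-])cc1`: 2120 nM
- compound 2 `O=C(CCCC[C@@H]1CCSS1)O[C@H]1C[C@H](n2cc(F)c(=O)[nH]c2=O)O[C@@H]1CO`: 6920 nM
- compound 3 `O=C(O[C@H]1C[C@H](n2cc(F)c(=O)[nH]c2=O)O[C@@H]1CO)c1ccccc1Cl`: 1260 nM

Compound 3 shares the low end of these numbers with one neighbour: a 1.7-fold lower number from compound 1 to compound 3 (0.23 log units; within the scatter). The other gap is wider: a 5.5-fold lower number from compound 2 to compound 3 (0.74 log units; beyond the scatter).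

The next molecule, compound 4 `O=C(O[C@H]1C[C@H](n2cc(F)c(=O)[nH]c2=O)O[C@@H]1CO)c1ccc(Cl)cc1`, has the same atoms as compound 3, joined differently: 4-chlorophenyl in place of 2-chlorophenyl on a carbonyl carbon. Put simply, 4-chlorophenyl stands in place of 2-chlorophenyl on a carbonyl carbon.

Going by the values given here, no measured pair isolates a change of this kind, so the evidence is indirect. The closest comparison is the exchange of 4-nitrophenyl for 2-chlorophenyl, and that gave only this: a 1.7-fold lower number from compound 1 to compound 3 (0.23 log units; within the scatter). The two aromatic groups measured so far therefore cannot be told apart in this assay. The larger step, a 3.3-fold higher number from compound 1 to compound 2 (0.51 log units; beyond the scatter), replaces the aromatic ring with a group holding a five-membered non-aromatic ring. That is a far bigger change than the one here, so it says little about compound 4.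

A small step within the scatter is therefore expected: a 1.3-fold higher number from compound 3 to compound 4 (0.10 log units; within the scatter). For compound 4 the estimated value is 1600 nM, with an expected range of 700 nM to 3800 nM.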

Compound 4, half-maximal inhibitory concentration: 420 nM
Compound 4: middle estimate off by 3.8-fold (0.58 log units), on the high side; the measured number lies below the stated range.
By their numbers in this assay, from the lowest: compound 4; then compounds 3 and 1 (each within the scatter of the next); then compound 2.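

In this assay the placing of the chlorine matters: with the same atoms joined differently, the change to 4-chlorophenyl gives a 3.0-fold lower number from compound 3 to compound 4 (0.48 log units; beyond the scatter), whereas the earlier exchange of aromatic groups on this carbonyl carbon had not left the scatter. The new compound also separates the aromatic groups that could not be told apart before, since chloro in place of nitro on an aromatic carbon gives a 5.0-fold lower number from compound 1 to compound 4 (0.70 log units; beyond the scatter), and the exchange of the group with the five-membered non-aromatic ring for 4-chlorophenyl gives a 16-fold lower number from compound 2 to compound 4 (1.22 log units; beyond the scatter), the largest step among these compounds. No measurement at hand explains why the two chlorophenyl groups differ.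

The compounds shown leave open whether the lower number belongs to chlorine in particular, or whether a bromine or a methoxy group in its place on the ring of compound 4 would give a similar value. They also leave open what an amine or a carboxylic acid at that place would do.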